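Cytotoxicity outlook for phenyl in place of pyridinyl

The source may hold more compounds than are shown below. What is called first, only, known or untested is meant among the compounds shown, and "the series" means these compounds.

The series shares one core with a secondary amine whose aryl partner is varied. Compound 1 `CC1(C)C[C@H](O)C[C@](C)(CNc2nc3ccc(F)cc3s2)C1` in an ADME assay on MDCK cells (Canis lupus familiaris) for cytotoxicity, read by MTT assay, with a stated time of 3 days (a lower number here means that less compound is tolerated, a higher number that more compound is tolerated), gives 16200 nM. Compound 2 `CC1(C)C[C@H](O)C[C@](C)(CNc2ccccn2)C1` carries pyridin-2-yl on that nitrogen; in this assay compound 2 gives > 100000 nM, which is a limit of the assay and not a number (the limit of > 100000 nM in this assay, at which 1 of the 3 values shown sits). Compound 3 `CC1(C)C[C@H](O)C[C@](C)(CNc2ccc(C(F)(F)F)cn2)C1` adds trifluoromethyl on an aromatic carbon and in this assay gives 30500 nM; the step of an at least 3.2-fold lower number from compound 2 to compound 3 (0.51 log units; beyond the scatter). Going by the values given here, compound 2 is thus the only member reported as a limit alone, with no number for it.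

The step to compound 4 `CC1(C)C[C@H](O)C[C@](C)(CNc2ccccc2)C1` is phenyl in place of pyridin-2-yl on an amine nitrogen. Among the compounds with values here, no measured step removes the ring hetero atom; the only step from compound 2 is an at least 3.2-fold lower number from compound 2 to compound 3 (0.51 log units; beyond the scatter), which shows a substituent on the ring pulling the number off the limit. Compound 1 sits lower at 16200 nM. Since both rings are six-membered and unsubstituted, only a small to modest downward move is expected, with a real chance that compound 4 again reaches the limit. The expected step is an at least 1.4-fold lower number from compound 2 to compound 4 (0.15 log units; that floor lies within the scatter). Compound 4 is estimated at 70000 nM, within 25000 nM to 150000 nM.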

Compound 4, half-maximal cytotoxic concentration: 37000 nM
Estimate against measurement, compound 4: 1.9-fold (0.28 log units) above, and the stated range covers the measured number.
By their numbers in this assay, from the lowest: compounds 1, 3 and 4 (each within the scatter of the next, the first and the last beyond it). At a limit, above all of these: compound 2.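

Replacing pyridin-2-yl with phenyl on an amine nitrogen in this assay gives an at least 2.7-fold lower number from compound 2 to compound 4 (0.43 log units; beyond the scatter), with no substituent added to the ring. Going by these compounds alone, until now the only step from compound 2 was the addition of trifluoromethyl, an at least 3.2-fold lower number from compound 2 to compound 3 (0.51 log units; beyond the scatter), so the earlier compounds left it unclear whether a number below the limit required a substituent; compound 4 shows that, in this pair, exchanging the ring alone is enough. From the compounds shown here alone, compound 2 is reported only as a limit of the assay and not as a number, so the true size of the step from pyridin-2-yl to phenyl stays unknown and only its floor can be read: the limit of > 100000 nM in this assay, at which 1 of the 4 values shown sits.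

Going by these compounds, whether trifluoromethyl on the phenyl of compound 4 would shift the number as it does on the pyridin-2-yl ring of compound 2 remains open. Also open, on these data alone, is how a carboxylic acid or an amine on the phenyl would read in this assay, and whether either would return the number to the limit.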